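A few compounds are considered here, and "the series" means these few. Any claim that something is new, unique, unknown or untested is made for them only; others in the source may bear on it.

Working notes on the series in a functional assay on LNCaP cells (Homo sapiens) for antiproliferative activity, read by propidium iodide staining, with a stated time of 96 h; on this read-out lower numbers stand for stronger inhibition and higher numbers for weaker inhibition. Compound 2 (`CC(O)(CS(=O)(=O)c1cccc(C(F)(F)F)c1)C(=O)Nc1cccc(S(F)(F)(F)(F)F)c1`) gives 21800 nM. Compound 1 (`CC(O)(CS(=O)(=O)c1cc(C(F)(F)F)cc(C(F)(F)F)c1)C(=O)Nc1ccc(S(F)(F)(F)(F)F)cc1`) gives 13300 nM, within the scatter of compound 2. Within the data shown here, compound 3 (`CC(O)(CS(=O)(=O)c1ccccc1OC(F)(F)F)C(=O)Nc1cccc(S(F)(F)(F)(F)F)c1`) gives 9000 nM, the one value clearly apart from compound 2.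

Compound 4 (`CC(O)(CS(=O)(=O)c1cc(C(F)(F)F)cc(C(F)(F)F)c1)C(=O)Nc1cccc(S(F)(F)(F)(F)F)c1`) follows from compound 2 by a single change: trifluoromethyl in place of hydrogen on an aromatic carbon. Among the measured compounds shown here, no measured step makes this exact change. The closest evidence is a modest change of the group on the sulfonyl sulfur, a 2.4-fold lower number from compound 2 to compound 3 (0.38 log units; beyond the scatter), which shows that this group can shift the number beyond the scatter. Compound 1, at 13300 nM, carries the same group on the sulfonyl sulfur as compound 4 but differs from it elsewhere, so it is only a rough guide. A small move towards a lower number is therefore expected, but nothing beyond the scatter. The expected step is a 1.6-fold lower number from compound 2 to compound 4 (0.19 log units; within the scatter). For compound 4 the estimated value is 14000 nM, with an expected range from 6000 nM to 30000 nM.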

Compound 4, half-maximal inhibitory concentration: 9700 nM
Beside the measured number, compound 4's estimate is 1.4-fold (0.16 log units) above it; low and high end bracket the measured number.
By their numbers in this assay, from the lowest: compounds 3, 4, 1 and 2 (each within the scatter of the next, the first and the last beyond it).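

In this assay, among these compounds, the added trifluoromethyl, on an aromatic carbon meta to a trifluoromethyl group, gives a 2.2-fold lower number from compound 2 to compound 4 (0.35 log units; beyond the scatter) and so provides the first measured step at this position, one that lies beyond the scatter. With this trifluoromethyl in place, the change of the group on the amide-type nitrogen gives a 1.4-fold lower number from compound 1 to compound 4 (0.14 log units; within the scatter) and does not separate the two compounds. No measurement shown here accounts for the step at the aromatic carbon.

As far as these compounds go, whether an amine or a carboxylic acid on this aromatic carbon would shift the number in the same direction stays open. Also open, from the compounds shown here alone, is whether the trifluoromethyl step carries over to the group on the amide-type nitrogen found in compound 1.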